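Propyl for isopropyl on a second core

The source may report more compounds than this note shows. Statements on the series, on what has been measured and on what is new or still open speak of the compounds shown alone.

Compound 1 `COc1cc2ncnc(N3CCc4ccccc43)c2cc1NC(=O)/C=C/C(C)C` is measured in a functional assay on PC-3 cells (Homo sapiens) for antiproliferative activity, read by MTT assay, with a stated time of 72 h (on this read-out higher numbers stand for weaker inhibition and lower numbers for stronger inhibition), where compound 1 gives 6530 nM. Compound 2 `CCC/C=C/C(=O)Nc1cc2c(N3CCc4ccccc43)ncnc2cc1OC` carries the change (propyl in place of isopropyl on a double-bonded chain carbon bound to a double-bonded chain carbon); in this assay compound 2 gives 4240 nM, a step of a 1.5-fold lower number from compound 1 to compound 2 (0.19 log units; within the scatter). Compound 3 `CC(C)/C=C/C(=O)Nc1cc2c(N3CCc4ccccc43)ncnc2cc1O[C@@H]1CCOC1` differs from compound 1 in its core by oxolan-3-yl in place of methyl on an oxygen on an aromatic ring, and in this assay compound 3 gives 11200 nM, a step of a 1.7-fold higher number from compound 1 to compound 3 (0.23 log units; within the scatter). Compound 4 `CCC/C=C/C(=O)Nc1cc2c(N3CCc4ccccc43)ncnc2cc1O[C@@H]1CCOC1` has not yet been measured; it differs from compound 3 by propyl in place of isopropyl on a double-bonded chain carbon bound to a double-bonded chain carbon, the same change that takes compound 1 to compound 2, at the same place, here set on the core of compound 3. For the measured compounds named here, because the step of a 1.5-fold lower number from compound 1 to compound 2 (0.19 log units; within the scatter) lay within the scatter, the author expects a step of about the same size, a 1.5-fold lower number from compound 3 to compound 4 (0.17 log units; within the scatter), for the change from compound 3 to compound 4, resting only on that single precedent and on the single pair of cores. For compound 4 in this assay the estimate is 7500 nM, with a range from 3500 nM to 16000 nM.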

Compound 4, half-maximal inhibitory concentration: 9230 nM
For compound 4 the middle estimate is 1.2-fold (0.09 log units) below the measured one, and the stated range covers the measured number.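

In this assay, propyl in place of isopropyl on the second core gives a 1.2-fold lower number from compound 3 to compound 4 (0.08 log units; within the scatter), and this agrees with the same change on the first core: the same change on two cores in this assay, a 1.5-fold lower number (0.19 log units; within the scatter) from compound 1 to compound 2 and a 1.2-fold lower number (0.08 log units; within the scatter) from compound 3 to compound 4, 1.3-fold (0.10 log units) apart, within the scatter of two such steps

Oxolan-3-yl in place of methyl on an oxygen on an aromatic ring, read with propyl on the chain, gives a 2.2-fold higher number from compound 2 to compound 4 (0.34 log units; beyond the scatter), and this also agrees with its earlier counterpart: the same change on two cores in this assay, a 1.7-fold higher number (0.23 log units; within the scatter) from compound 1 to compound 3 and a 2.2-fold higher number (0.34 log units; beyond the scatter) from compound 2 to compound 4, 1.3-fold (0.10 log units) apart, within the scatter of two such steps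

Each change therefore carries across this one pair of cores with a similar size, but neither swap is shown to work the same way on any other core, and the propyl steps show no real effect of that change in either case.

From the compounds shown here alone, it remains open what a longer chain or an amine in place of propyl would do on either core. It is equally open whether a piperidine in place of oxolan-3-yl on the oxygen would keep the numbers of these compounds in the same range.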